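This account rests on a few compounds, and the source may have more. Where it says the series, first, only, none or still open, it means among the compounds named here.

For the measured compounds named here, in a functional assay on A2780 cells (Homo sapiens) for cytotoxicity (on this read-out lower numbers stand for stronger inhibition and higher numbers for weaker inhibition), two compounds have numbers so far. Compound 1 `CCc1cnc(CSc2cnc(NC(C)=O)s2)o1` gives 1400 nM, and compound 2 `CC(C)(C)C(=O)Nc1ncc(SCc2ncc(C(C)(C)C)o2)s1` gives 250 nM. Compound 2 therefore holds the lower of the two numbers, and its gap to compound 1 lies beyond the scatter. The two differ in more than one place, so that gap cannot be tied to any single change.

Compound 3 `CCNC(=O)Nc1ncc(SCc2ncc(C(C)(C)C)o2)s1` has not yet been measured. It carries ethylamino in place of tert-butyl on a carbonyl carbon, which turns ((tert-butyl)carbonyl)amino into (ethylcarbamoyl)amino. Going by the values given here, no measured pair shows this change on its own, so the expectation in this assay is only a cautious one. The estimated step of a 1.3-fold higher number from compound 2 to compound 3 (0.11 log units; within the scatter) is expected to stay within the scatter, leaning slightly towards a higher number. For compound 3 the expected value is 320 nM, with an estimated range from 90 nM to 1100 nM.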

Compound 3, half-maximal inhibitory concentration: 120 nM
The estimate for compound 3 lay 2.7-fold (0.43 log units) above the measured number; the measured number falls inside the stated range.
By their numbers in this assay, from the lowest: compound 3; then compound 2; then compound 1.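

In this assay, for the compounds shown here, ethylamino in place of tert-butyl on a carbonyl carbon gives a 2.1-fold lower number from compound 2 to compound 3 (0.32 log units; beyond the scatter) and is the first difference that can be tied to a single change. The step is modest, but it shows that the number responds to what sits on this carbonyl carbon and that tert-butyl can give way to ethylamino, which brings a nitrogen and a hydrogen-bond donor, without any loss in this read-out. Nothing available explains why the number falls. From the compounds shown here alone, whether the nitrogen or the ethyl chain matters more stays open, as does whether methylamino, propylamino or morpholine on the same carbonyl carbon would move the number the same way. Going by these compounds, it is also open whether this change would give a similar step in the setting of compound 1.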